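Aryl returns in place of cyclopropyl on the triazole

The source may hold more compounds than are shown below. What is called first, only, known or untested is meant among the compounds shown, and "the series" means these compounds.

Three analogues sharing one core have been measured in a functional assay on HeLa cells (Homo sapiens) for antiproliferative activity, read by MTT assay, with a stated time of 72 h; on this read-out lower numbers stand for stronger inhibition and higher numbers for weaker inhibition. Compound 1 `O=C1O[C@H]([C@@H](O)Cn2cc(-c3ccc(Br)cc3)nn2)C(OCc2ccccc2)=C1OCc1ccccc1` gives 3910 nM. Compound 2 `CCCCCc1ccc(-c2cn(C[C@H](O)[C@H]3OC(=O)C(OCc4ccccc4)=C3OCc3ccccc3)nn2)cc1` gives 8390 nM. Compound 3 `O=C1O[C@H]([C@@H](O)Cn2cc(C3CC3)nn2)C(OCc2ccccc2)=C1OCc1ccccc1` gives 26500 nM, the highest number of the three and therefore the weakest inhibitor of the set, since both of its steps lie beyond the scatter. The steps leading to it are a 6.8-fold higher number from compound 1 to compound 3 (0.83 log units; beyond the scatter) and a 3.2-fold higher number from compound 2 to compound 3 (0.50 log units; beyond the scatter); the pair of aryl compounds themselves differ by a 2.1-fold higher number from compound 1 to compound 2 (0.33 log units; beyond the scatter).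

Compound 4 `O=C1O[C@H]([C@@H](O)Cn2cc(-c3cc(F)cc(F)c3)nn2)C(OCc2ccccc2)=C1OCc1ccccc1` has not yet been measured. It differs from compound 3 by 3,5-difluorophenyl in place of cyclopropyl on an aromatic carbon. This change runs against the direction of the two steps that ended at compound 3, since an aromatic six-membered ring again replaces the cyclopropyl. Both of those steps raised the number when the aryl was removed, so its return is expected to lower it, by an amount between the two observed steps.

On that basis compound 4 is expected to show a 4.5-fold lower number from compound 3 to compound 4 (0.65 log units; beyond the scatter) in this assay. The estimate for compound 4 is 5900 nM, with a range from 2500 nM to 14000 nM.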

Compound 4, half-maximal inhibitory concentration: 40800 nM
Compound 4: the middle estimate sits 6.9-fold (0.84 log units) below what was measured, outside the stated range (above it).
By their numbers in this assay, from the lowest: compound 1; then compound 2; then compounds 3 and 4 (each within the scatter of the next).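

In this assay, restoring an aromatic six-membered ring at this carbon of the five-membered aromatic ring does not by itself restore the activity seen with the earlier aryl compounds: 3,5-difluorophenyl in place of cyclopropyl gives no separable change (a 1.5-fold higher number from compound 3 to compound 4 (0.19 log units; within the scatter)). The earlier compounds shown here made the aryl ring look sufficient, but compound 4 goes against that pattern, so what the ring carries matters as well: replacing 4-pentylphenyl with 3,5-difluorophenyl gives a 4.9-fold higher number from compound 2 to compound 4 (0.69 log units; beyond the scatter), and replacing 4-bromophenyl with it gives a 10-fold higher number from compound 1 to compound 4 (1.02 log units; beyond the scatter), the largest step in the set. Nothing available here accounts for this dependence on the aryl group.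

The compounds shown leave open whether the gap between the aryl compounds follows from the identity of their substituents, from their number, or from where they sit on the ring. Also unresolved is how an unsubstituted phenyl, or an aryl ring carrying a methoxy group or an amine, would stand against compound 1 and compound 4 at this carbon.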